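Swapping the Aryl Tail on a Chemokine Receptor Ligand

A few compounds are considered here, and "the series" means these few. Any claim that something is new, unique, unknown or untested is made for them only; others in the source may bear on it.

Three compounds sharing one core were tested in an assay on THP-1 cells for displacement of a labelled ligand from C-C chemokine receptor type 1 (Homo sapiens); on this read-out higher numbers stand for weaker inhibition and lower numbers for stronger inhibition. Compound 1 `CC(C)C(NC(=O)c1ccccc1)C(=O)N1CCC(c2ccc(F)cc2)CC1` gives 423 nM. Compound 3 `CC(C)C(NC(=O)c1ccc2ccccc2c1)C(=O)N1CCC(c2ccc(Cl)cc2)CC1` gives 80 nM. Compound 2 `Cc1ccccc1CCC(=O)N[C@@H](C(=O)N1CCC(c2ccc(Cl)cc2)CC1)C(C)C` gives 19 nM, the lowest of the three numbers; compound 3 sits nearest, and compound 1 furthest, both beyond the scatter.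

Compound 4 `CC(C)[C@@H](NC(=O)CCc1ccc(F)cc1)C(=O)N1CCC(c2ccc(Cl)cc2)CC1` has not yet been measured in this assay. It differs from compound 2 in one place: 4-fluorophenyl in place of 2-methylphenyl on a saturated chain carbon, two bonds along the chain from a carbonyl carbon. Read one bond further out, the change is 2-(2-methylphenyl)ethyl to 2-(4-fluorophenyl)ethyl.

For the measured compounds named here, no measured pair shows this exact change, so the expectation rests on compound 2 alone. Because compound 2 gives 19 nM and the swap keeps the chain and the ring count, the step is expected to be small, either none beyond the scatter or a modest rise; the estimated step is a 1.7-fold higher number from compound 2 to compound 4 (0.23 log units; within the scatter). Compound 4 is estimated at 32 nM, within a range from 10 nM to 100 nM.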

Compound 4, half-maximal inhibitory concentration: 70 nM
Beside the measured number, compound 4's estimate is 2.2-fold (0.34 log units) below it; measured number inside the range.
By their numbers in this assay, from the lowest: compound 2; then compounds 4 and 3 (each within the scatter of the next); then compound 1.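

The place on a saturated chain carbon, two bonds along the chain from a carbonyl carbon, proves sensitive to the aryl group it carries: in this assay replacing 2-methylphenyl with 4-fluorophenyl gives a 3.7-fold higher number from compound 2 to compound 4 (0.57 log units; beyond the scatter) even though both groups have the same heavy atom count, one six-membered aromatic ring of carbon only, and no hydrogen-bond donors or acceptors. Those shared counts therefore do not settle the number at this place. Nothing at hand explains the step.

The methyl group leaves and the fluorine enters in a single change, so this pair cannot show which of them carries the step; phenyl, 4-methylphenyl or 2-fluorophenyl on the same chain would separate the two. Also open, as far as these compounds go, is how a longer chain or an amine on the ring would read here.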